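A Cyano Group Added to Compound 1

The compounds below may be only part of what the source reports. "The series", "measured", "known", "first", "only" and "open" are said of these compounds alone.

Of the compounds shown here, two have so far been measured in a functional assay on NCI-H2228 cells (Homo sapiens) for inhibition, read by CellTiter-Glo, with a stated time of 96 h; on this read-out lower numbers stand for stronger inhibition and higher numbers for weaker inhibition. Compound 1 (`CC(C)S(=O)(=O)c1nn(C)cc1Nc1nc(Nc2ccc(C3CCN(C)CC3)cc2OC2CC2)ncc1Cl`) gives 36 nM, and compound 2 (`Cc1cc(Nc2ncc(Cl)c(Nc3cn(C)nc3S(=O)(=O)C(C)C)n2)c(OC(C)C)cc1C1CCN(C)C1`) gives 131 nM. Compound 1 therefore holds the lower of the two numbers, and the gap to compound 2 lies beyond the usual scatter. The two compounds differ in more than one place, so that gap cannot be tied to any single change.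

Compound 3 (`CC(C)S(=O)(=O)c1nn(C)cc1Nc1nc(Nc2cc(C#N)c(C3CCN(C)CC3)cc2OC2CC2)ncc1Cl`) keeps compound 1 intact apart from one change (cyano in place of hydrogen on an aromatic carbon). A cyano group takes the place of a hydrogen on an aromatic carbon, ortho to the 1-methylpiperidin-4-yl group and para to the cyclopropyloxy group. For the measured compounds named here, no measured pair shows this change, so the expectation is loose and the range is wide. What is expected in this assay is a 1.7-fold higher number from compound 1 to compound 3 (0.22 log units; within the scatter) and so a modest move toward a higher number, one that may not clear the scatter. Compound 3 is estimated at 60 nM, with an expected range from 20 nM to 170 nM.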

Compound 3, half-maximal inhibitory concentration: 165 nM
Compound 3: middle estimate off by 2.8-fold (0.44 log units), on the low side; low and high end bracket the measured number.
By their numbers in this assay, from the lowest: compound 1; then compounds 2 and 3 (each within the scatter of the next).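

With compound 3, the study gains its first pair that differs in only one place, and in this assay that step is a 4.6-fold higher number from compound 1 to compound 3 (0.66 log units; beyond the scatter). It shows that this aromatic carbon, ortho to a 1-methylpiperidin-4-yl group and para to a cyclopropyloxy group, is not indifferent to substitution: with cyano in place of hydrogen, the number rises beyond the scatter, and the compound with hydrogen there keeps the lower number. No accompanying measurement bears on why the number rises, so the step stands as an observation without an explanation.

With cyano as the only group shown on this carbon, a single step cannot tell whether the rise belongs to cyano itself or would follow any group placed there. A fluorine atom, a methoxy group or a primary amide on the same carbon of compound 1 would help separate those two readings, and the same cyano group on another carbon of this ring would show how far the result is specific to this position.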